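The compounds below may be only part of what the source reports. "The series", "measured", "known", "first", "only" and "open" are said of these compounds alone.

Two compounds of a shared core carrying a cinnamoyl-type side chain have been measured in a functional assay on HSC-4 cells (Homo sapiens) for cytotoxicity, with a stated time of 48 h; on this read-out lower numbers stand for higher toxicity in this test and higher numbers for lower toxicity in this test. Compound 1 `Cc1c(C(=O)/C=C/c2cccc([N+](=O)[O-])c2)[n+]([O-])c2ccccc2[n+]1[O-]` carries a nitro group on its terminal ring, and in this assay compound 1 gives 54000 nM. Compound 2 `Cc1c(C(=O)/C=C/c2ccc(Cl)cc2)[n+]([O-])c2ccccc2[n+]1[O-]` carries a chloro group on that ring instead, and in this assay compound 2 gives 19000 nM. On these two numbers compound 2 stands lowest: the value of compound 1 is higher than that of compound 2 by a margin beyond the usual scatter, so compound 2 is the more toxic of the two in this assay.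

Compound 3 `Cc1ccc(/C=C/C(=O)c2c(C)[n+]([O-])c3ccccc3[n+]2[O-])cc1` has not yet been measured in this assay. It differs from compound 2 in one place: methyl in place of chloro on an aromatic carbon. For the measured compounds named here, no measured pair in this set separates a chloro from a methyl group, so no step of that kind is known here. With nothing but the two values of compound 1 and compound 2 to go on, compound 3 is expected to land close to compound 2, with a step from compound 2 to compound 3 of a 1.3-fold higher number from compound 2 to compound 3 (0.12 log units; within the scatter) that lies within the scatter. For compound 3 the estimated value in this assay is 25000 nM, within a range of 10000 nM to 60000 nM.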

Compound 3, half-maximal cytotoxic concentration: 11000 nM
For compound 3 the middle estimate is 2.3-fold (0.36 log units) above the measured one; the measured number falls inside the stated range.
By their numbers in this assay, from the lowest: compounds 3 and 2 (each within the scatter of the next); then compound 1.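

In this assay the exchange of chloro for methyl on an aromatic carbon, para to a large group, gives a 1.7-fold lower number from compound 2 to compound 3 (0.24 log units; within the scatter) and so stays within the usual scatter of repeated measurements. For the compounds shown here, this is the first step in the set that can be read at a single place, since the earlier compounds were not linked by any such step, and it shows that on this read-out 4-chlorophenyl and 4-methylphenyl cannot be told apart at this position of the terminal ring. No measured property of these compounds is at hand that bears on this result.

The compounds shown leave open whether a group of another kind at this same position, such as an amine, a carboxylic acid or a longer chain, would move the number beyond the scatter. They also leave open whether chloro and methyl would remain as hard to separate on a terminal ring that carries a further group, or on a shared core altered elsewhere, for example with an ethyl group in place of its methyl group.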